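This account rests on a few compounds, and the source may have more. Where it says the series, first, only, none or still open, it means among the compounds named here.

Measured compounds in this series:
- compound 1 `CSc1ncnc2c1c(-c1ccccc1)cn2[C@@H]1O[C@H](CO)[C@@H](O)[C@H]1O`: > 20000 nM (a limit of the assay, not a number)
- compound 2 `CSc1ncnc2c1c(-c1ccsc1)cn2[C@@H]1O[C@H](CO)[C@@H](O)[C@H]1O`: 4590 nM
- compound 3 `Nc1nc2c(c(-c3ccccc3)cn2[C@@H]2O[C@H](CO)[C@@H](O)[C@H]2O)c(=O)[nH]1`: > 20000 nM (a limit of the assay, not a number)

In a functional assay on HL-60 cells (Homo sapiens) for antiproliferative activity, read by XTT assay, with a stated time of 72 h (a lower number here means a stronger inhibitor, a higher number a weaker inhibitor), compound 1 gives > 20000 nM, which is a limit of the assay and not a number. In this assay compound 2 gives 4590 nM. The step between them, an at least 4.3-fold lower number from compound 1 to compound 2 (0.63 log units; beyond the scatter), is the single change thiophen-3-yl in place of phenyl on an aromatic carbon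
Since compound 1 reaches only a limit, the true size of that step is open at the upper end; what is known is the limit of > 20000 nM in this assay, at which 2 of the 3 values shown sit.

Compound 3 gives > 20000 nM in this assay, again a limit of the assay and not a number. The difference between the core of compound 3 and the core of compound 1 is not broken down here.

Compound 4 `Nc1nc2c(c(-c3ccsc3)cn2[C@@H]2O[C@H](CO)[C@@H](O)[C@H]2O)c(=O)[nH]1` is not yet measured in this assay. It stands to compound 3 as compound 2 stands to compound 1, by the same change thiophen-3-yl in place of phenyl on an aromatic carbon
The step from compound 3 to compound 4 is expected to be of a similar direction, an at least 2.2-fold lower number from compound 3 to compound 4 (0.34 log units; beyond the scatter), resting on the measured step of an at least 4.3-fold lower number from compound 1 to compound 2 (0.63 log units; beyond the scatter). Because compound 3 sits at the limit > 20000 nM, the starting point is itself unknown, so the end point is uncertain and a further limit is a real possibility. The estimate for compound 4 in this assay is 9000 nM, with an expected range from 2500 nM to 25000 nM.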

Compound 4, half-maximal inhibitory concentration: > 20000 nM
Compound 4 ended at the assay's limit; the forecaster's own chance of this, stated with the estimate: 45%; at least 2.2-fold (0.34 log units) between middle value and limit.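

In this assay compound 4 gives > 20000 nM as a limit of the assay and not a number. Compound 3 also stands at a limit, so no step can be read between compound 3 and compound 4: the limit of > 20000 nM in this assay, at which 3 of the 4 values shown sit.

The compounds shown leave open whether thiophen-3-yl in place of phenyl lowers the number on the core of compound 3 as it does on the core of compound 1.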